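Swapping fluoro for trifluoromethyl on compound 2

This account rests on a few compounds, and the source may have more. Where it says the series, first, only, none or still open, it means among the compounds named here.

In a functional assay on HepG2 cells (Homo sapiens) for cytotoxicity, read by MTT assay, with a stated time of 24 h (a lower number here means a stronger inhibitor, a higher number a weaker inhibitor), compound 2 `O=C1/C(=C/c2cccnc2)CNC/C1=C\c1ccccc1F` gives 21000 nM, which lies within the scatter of compound 3 `O=C1/C(=C/c2cccnc2)CN(S(=O)(=O)c2ccc(Cl)cc2)C/C1=C\c1ccccc1F` at 12400 nM. Compound 1 `CN1C/C(=C\c2cccnc2)C(=O)/C(=C/c2ccccc2C(F)(F)F)C1`, at 2550 nM, has a much lower number than compound 2, which therefore sits at the high end of this small set.

Compound 4 `O=C1/C(=C/c2cccnc2)CNC/C1=C\c1ccccc1C(F)(F)F` departs from compound 2 in one place: trifluoromethyl in place of fluoro on an aromatic carbon. Among the measured compounds shown here, the one measured single change, a 1.7-fold lower number from compound 2 to compound 3 (0.23 log units; within the scatter), lies on an amine nitrogen in a ring, so it says little about this swap. For the measured compounds named here, compound 1 is the only measured compound carrying trifluoromethyl, and its 2550 nM hints at a lower number. It also has a methyl group on that ring nitrogen, however, so the hint is weak and only part of that gap is carried over. The step expected in this assay is therefore moderate: a 2.3-fold lower number from compound 2 to compound 4 (0.37 log units; beyond the scatter). For compound 4 the estimated value is 9000 nM, with an expected range from 3000 nM to 25000 nM.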

Compound 4, half-maximal inhibitory concentration: 5020 nM
For compound 4 the middle estimate is 1.8-fold (0.25 log units) above the measured one; low and high end bracket the measured number.
By their numbers in this assay, from the lowest: compounds 1 and 4 (each within the scatter of the next); then compounds 3 and 2 (each within the scatter of the next).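

On the aromatic carbon, trifluoromethyl in place of fluoro gives a 4.2-fold lower number from compound 2 to compound 4 (0.62 log units; beyond the scatter) in this assay, the first single change measured at this position and one that lies beyond the scatter. On the ring nitrogen, hydrogen in place of methyl gives a 2.0-fold higher number from compound 1 to compound 4 (0.29 log units; within the scatter), which stays within the scatter, so in these compounds the swap on the aromatic carbon is the change that registers clearly. Nothing measured here explains why the number shifts with this swap.

As far as these compounds go, with only fluoro and trifluoromethyl to compare at this aromatic carbon, it remains open how a methoxy group or a nitrile would behave there. Also open, from the compounds shown here alone, is whether the same step would appear with (4-chlorophenyl)sulfonyl on the ring nitrogen.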